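A few compounds are considered here, and "the series" means these few. Any claim that something is new, unique, unknown or untested is made for them only; others in the source may bear on it.

Measured so far:
compound 1, `CC(C)CN1CCc2nc(C#Cc3ccccc3)sc2C1`: 650 nM in an assay on HEK293 cells for negative allosteric modulation of metabotropic glutamate receptor 5 (Homo sapiens), read by FLIPR, with a stated time of 1 h; on this read-out lower numbers stand for stronger inhibition and higher numbers for weaker inhibition
compound 2, `Fc1cccc(C#Cc2nc3c(s2)CN(C2CCC2)CC3)c1`: 200 nM in this assay
compound 3, `O=C(C1CC(F)(F)C1)N1CCc2nc(C#Cc3cccc(F)c3)sc2C1`: a limit of the assay, > 10000 nM in this assay

In this assay compound 1 stands highest of the two numbers, and compound 2 sits lower, beyond the scatter. Compound 3 gives no number but only (the limit of > 10000 nM in this assay, at which 1 of the 3 values shown sits). Compound 4, `COC1CC(C(=O)N2CCc3nc(C#Cc4ccccc4)sc3C2)C1`, differs from compound 1 by (3-methoxycyclobutyl)carbonyl in place of isobutyl on an amine nitrogen in a ring. Among the measured compounds shown here, one measured step bears on this change: an at least 50-fold higher number from compound 2 to compound 3 (1.69 log units; beyond the scatter), which also put a carbonyl-linked cyclobutyl ring on the same ring nitrogen and was large. The same kind of large loss is therefore expected here, and compound 4 is expected to give 12000 nM, with a range from 3000 nM to 40000 nM, a step of an 18-fold higher number from compound 1 to compound 4 (1.27 log units; beyond the scatter), quite possibly reported only as a limit.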

Compound 4, half-maximal inhibitory concentration: > 10000 nM
Compound 4: no number, only a limit; the forecaster's own chance of this, stated with the estimate: 60%; the middle value lies beyond the limit too.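

Putting (3-methoxycyclobutyl)carbonyl in place of isobutyl on this amine nitrogen in a ring brings an at least 15-fold higher number from compound 1 to compound 4 (1.18 log units; beyond the scatter), so the large loss is not tied to the difluorinated group of an at least 50-fold higher number from compound 2 to compound 3 (1.69 log units; beyond the scatter). It also appears on the core of compound 1, which has a different aryl end from compound 2. Both steps end at a limit of the assay and not at a number, so their full size stays unknown: the limit of > 10000 nM in this assay, at which 2 of the 4 values shown sit.

The compounds shown leave open whether the carbonyl alone is enough for this loss. A small acetyl group or a methyl carbamate on this nitrogen would test that.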